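This account rests on a few compounds, and the source may have more. Where it says the series, first, only, none or still open, it means among the compounds named here.

For the measured compounds named here, compound 2, `O=C(NC1CCN(Cc2ccc(C(F)(F)F)cc2)CC1)c1cccc2ccccc12`, gives 96 nM in an assay on isolated protein for displacement of a labelled ligand from D(4) dopamine receptor (Homo sapiens) (a lower number here means a stronger inhibitor, a higher number a weaker inhibitor), the highest of the two numbers so far; its nearest neighbour is compound 1, `O=C(NC1CCN(Cc2ccc(Cl)cc2)CC1)c1cccc2ccccc12`, which in this assay gives 43 nM. Going by the values given here, the only measured step so far is a 2.2-fold higher number from compound 1 to compound 2 (0.35 log units; beyond the scatter), a modest shift that came from swapping one group on the aromatic ring bound to the piperidine-linked carbon. Compound 3, `COc1cccc(CN2CCC(NC(=O)c3cccc4ccccc34)CC2)c1`, differs from compound 2 by 3-methoxyphenyl in place of 4-(trifluoromethyl)phenyl on a saturated chain carbon bound to an amine nitrogen in a ring. Among the compounds with values here, no measured step here involves a methoxy group or a change of its position on that ring, so the step from compound 1 to compound 2 is the only guide, and it shows that swapping this ring's group moves the number modestly. Compound 3 is therefore expected to land close to the two measured values, with a 1.6-fold lower number from compound 2 to compound 3 (0.20 log units; within the scatter) as the likely step, giving an estimate of 60 nM and a range from 20 nM to 180 nM.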

Compound 3, inhibition constant: 168 nM
Compound 3: middle estimate off by 2.8-fold (0.45 log units), on the low side, within the range that was stated.
By their numbers in this assay, from the lowest: compound 1; then compounds 2 and 3 (each within the scatter of the next).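

In this assay (this assay), 3-methoxyphenyl in place of 4-(trifluoromethyl)phenyl gives a step that stays within the scatter (a 1.8-fold higher number from compound 2 to compound 3 (0.24 log units; within the scatter)), so these two quite different groups are not told apart at this position. Set against 4-chlorophenyl, the same 3-methoxyphenyl group gives a step beyond the scatter (a 3.9-fold higher number from compound 1 to compound 3 (0.59 log units; beyond the scatter)), which makes compound 1 the strongest of the three, with both of its replacements weaker. Nothing available here explains these differences.

Compound 3 changes both the group and its place on the ring, so the compounds shown cannot say how much each of those two changes contributes. On these data alone, whether a hydroxyl or an amine on this ring would match 4-chlorophenyl or improve on it also stays open.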